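The source may report more compounds than this note shows. Statements on the series, on what has been measured and on what is new or still open speak of the compounds shown alone.

Among the measured compounds shown here, in a functional assay on SW-620 cells (Homo sapiens) for antiproliferative activity, read by MTT assay, with a stated time of 24 h (a higher number here means a weaker inhibitor, a lower number a stronger inhibitor), compound 2 `COc1ccc(C(=O)/C=C/c2cccc([N+](=O)[O-])c2)c2c1C=CC(C)(C)O2` gives 4090 nM, and the only other number comes from compound 3 `COc1ccc(C(=O)/C=C/c2cccc(C(F)(F)F)c2)c2c1C=CC(C)(C)O2`, at 7870 nM. Compound 1 `COc1ccc(C(=O)/C=C/c2ccc(-n3ccnc3)cc2)c2c1C=CC(C)(C)O2` is reported only as a limit, > 10000 nM. Compound 4 `COc1ccc(C(=O)/C=C/c2cccs2)c2c1C=CC(C)(C)O2` has not yet been measured. It differs from compound 2 by thiophen-2-yl in place of 3-nitrophenyl on a double-bonded chain carbon bound to a double-bonded chain carbon, with thiophen-2-yl in place of 3-nitrophenyl. For the measured compounds named here, the one measured step that alters the 3-nitrophenyl group, trifluoromethyl in place of nitro, is a 1.9-fold higher number from compound 2 to compound 3 (0.28 log units; within the scatter). Going by the values given here, no measured step exchanges the whole ring, so this is only a loose guide. No change beyond the scatter is therefore expected in this assay, and the expected step is a 1.3-fold higher number from compound 2 to compound 4 (0.13 log units; within the scatter). For compound 4 the estimated value is 5500 nM, with an expected range of 2200 nM to 12000 nM.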

Compound 4, half-maximal inhibitory concentration: > 10000 nM
Compound 4: only a limit was reported; the forecaster's own chance of this, stated with the estimate: 25%; middle value at least 1.8-fold (0.25 log units) from the limit.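

Exchanging the whole ring at this position, thiophen-2-yl in place of 3-nitrophenyl, gives an at least 2.4-fold higher number from compound 2 to compound 4 (0.38 log units; beyond the scatter). The earlier swap on the ring, trifluoromethyl in place of nitro, gave only a 1.9-fold higher number from compound 2 to compound 3 (0.28 log units; within the scatter), so the position is not indifferent to what is placed there. The step is only a lower bound, since the reading for compound 4 is a limit of the assay: the limit of > 10000 nM in this assay, at which 2 of the 4 values shown sit.

From the compounds shown here alone, how far compound 4 lies past that limit stays open, and so does any order between compound 1 and compound 4. Also open, going by these compounds, is whether a furan-2-yl ring or a phenyl ring carrying an amine would behave like 3-nitrophenyl or like thiophen-2-yl.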